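Series notes: hydroxy at the end of the butylamino chain

The source may hold more compounds than are shown below. What is called first, only, known or untested is meant among the compounds shown, and "the series" means these compounds.

Measured so far in an assay on CHO cells for displacement of a labelled ligand from adenosine receptor A1 (Homo sapiens), read by scintillation counting, with a stated time of 1 h, tested at 1 uM; on this read-out higher numbers stand for more inhibition at the one concentration tested (going by the name of the read-out) and lower numbers for less inhibition:
compound 1, `O=C(Nc1ncc(-c2cccc(Cl)c2)c(-c2ccccc2)n1)C1CCC1`, gives 52%
compound 2, `CNc1ncc(-c2cccc(Cl)c2)c(-c2ccccc2)n1`, gives 75%
compound 3, `CCCCNc1ncc(-c2cccc(Cl)c2)c(-c2ccccc2)n1`, gives 56%

Compound 3 stands second highest of the three numbers. Its nearest neighbour is compound 1: the step of a number 4 percentage points higher from compound 1 to compound 3 (within the scatter) lies within the usual scatter, so the two are not distinguished. Its furthest is compound 2: the step of a number 19 percentage points lower from compound 2 to compound 3 (beyond the scatter) lies beyond the scatter, a modest loss on lengthening the group on the ring nitrogen.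

Compound 4, `OCCCCNc1ncc(-c2cccc(Cl)c2)c(-c2ccccc2)n1`, differs from compound 3 in one place: hydroxy in place of hydrogen on a saturated chain carbon, four bonds along the chain from a nitrogen on an aromatic ring.

The measured steps all concern what sits on the ring nitrogen: a number 23 percentage points higher from compound 1 to compound 2 (beyond the scatter), a number 4 percentage points higher from compound 1 to compound 3 (within the scatter) and a number 19 percentage points lower from compound 2 to compound 3 (beyond the scatter). None of them introduces a hydroxy, and none changes the chain at the position four bonds from the ring nitrogen while keeping its length. They show that this part of the molecule moves the number only modestly, and they give no direction for the present change. The expectation for compound 4 is therefore a step of a number 4 percentage points lower from compound 3 to compound 4 (within the scatter), not beyond the scatter, in this assay. Compound 4 is estimated at 52%, with a range from 30% to 72%.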

Compound 4, a percentage reported as inhibition, at one concentration (the size of the read-out at that concentration, not a potency): > 80%
Compound 4: a limit, no number (the forecaster's own chance of this, stated with the estimate: 0%); middle value at least 28 percentage points from the limit.
By their numbers in this assay, from the lowest: compounds 1 and 3 (each within the scatter of the next); then compound 2. At a limit, above all of these: compound 4.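

In this assay, compound 4 stands at a limit of the assay, not at a number: the limit of > 80% in this assay, at which 1 of the 4 values shown sits.

Hydroxy on the saturated chain carbon, four bonds along the chain from a nitrogen on an aromatic ring, is the first change at this position that keeps the chain length, and it gives a number at least 24 percentage points higher from compound 3 to compound 4 (beyond the scatter), so the end of the butylamino chain is not a place where changes go unnoticed. The other two comparisons read a number at least 5 percentage points higher from compound 2 to compound 4 (that floor lies within the scatter) and a number at least 28 percentage points higher from compound 1 to compound 4 (beyond the scatter): the loss seen on going from methyl to butyl does not persist once the chain carries the hydroxy, and the 4-hydroxybutyl chain clearly outdoes the cyclobutylcarbonyl group.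

On these data alone, the true size of these gains stays open, and whether compound 4 truly exceeds compound 2 cannot be said from that floor. Also open, as far as these compounds go, is whether the hydroxy itself is what counts, which a methoxy, an amine or a carboxylic acid at the chain end would test, and whether the effect holds on a shorter or longer chain carrying the same hydroxy.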